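The source may report more compounds than this note shows. Statements on the series, on what has been measured and on what is new or still open speak of the compounds shown alone.

Working notes on the amide series. Going by the values given here, compound 2 `CCn1c(C(=O)NCCN)ccc1C(CC)(CC)c1ccc(OCS(=O)(=O)c2ccccc2)c(C)c1` gives 6470 nM in a functional assay on MCF7 cells (Homo sapiens) for antiproliferative activity, read by MTT assay, with a stated time of 24 h (on this read-out lower numbers stand for stronger inhibition and higher numbers for weaker inhibition), the lowest of the two numbers so far available. Compound 3 `CCn1c(C(=O)N[C@@H](CO)CCCO)ccc1C(CC)(CC)c1ccc(OCS(=O)(=O)c2ccccc2)c(C)c1` gives 29600 nM in this assay, and the step of a 4.6-fold higher number from compound 2 to compound 3 (0.66 log units; beyond the scatter) shows a modest loss when the 2-aminoethyl is exchanged for a longer neutral chain. For compound 1 `CCn1c(C(=O)NCC(=O)OC)ccc1C(CC)(CC)c1ccc(OCS(=O)(=O)c2ccccc2)c(C)c1` this assay reports only a limit, > 50000 nM (the limit of > 50000 nM in this assay, at which 1 of the 3 values shown sits). Among the compounds with values here, the step of an at least 7.7-fold lower number from compound 1 to compound 2 (0.88 log units; beyond the scatter) is the one change in the set that moved a value from that limit into the measurable range.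

Compound 4 `CCn1c(C(=O)N[C@@H](CC(=O)O)C(=O)O)ccc1C(CC)(CC)c1ccc(OCS(=O)(=O)c2ccccc2)c(C)c1` carries the change (1,2-dicarboxyethyl in place of 2-aminoethyl on an amide-type nitrogen). Both informative steps bear on it: the 2-aminoethyl is again removed, as in the step from compound 2 to compound 3, and the group entering is a larger acid-bearing chain rather than a basic one, so a loss at least as large as that step is expected, possibly returning to the limit. Compound 4 is therefore expected near 30000 nM, within 10000 nM to 100000 nM. The expected step is a 4.6-fold higher number from compound 2 to compound 4 (0.67 log units; beyond the scatter).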

Compound 4, half-maximal inhibitory concentration: > 50000 nM
Compound 4: no number, only a limit; the forecaster's own chance of this, stated with the estimate: 45%; middle value at least 1.6-fold (0.22 log units) away from the limit.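

With 1,2-dicarboxyethyl on the amide-type nitrogen, the series returns to the limit of this assay, with an at least 7.7-fold higher number from compound 2 to compound 4 (0.88 log units; beyond the scatter). Against the chain of compound 3, the result is only an at least 1.6-fold higher number from compound 3 to compound 4 (0.22 log units; that floor lies within the scatter), so compound 3 and compound 4 cannot be ordered from these data. The step between compound 1 and compound 4 cannot be read, and only compound 2 and compound 3 now give numbers, with the remaining compounds at a limit: the limit of > 50000 nM in this assay, at which 2 of the 4 values shown sit.

Open, as far as these compounds go, is whether the amine of compound 2 or the length of its chain matters more; 3-aminopropyl, 2-(dimethylamino)ethyl or 2-hydroxyethyl on the same nitrogen would separate the two. A single carboxylic acid on a short chain, as in carboxymethyl, would show whether the limit of compound 4 requires both carboxyl groups.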